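This account rests on a few compounds, and the source may have more. Where it says the series, first, only, none or still open, it means among the compounds named here.

Compound 1, `N#CN/C(=N\CCOC(=O)c1ccccc1)NCCCOc1cccc(CN2CCCCC2)c1`, and compound 2, `N#CN/C(=N\CCCNc1ccccc1[N+](=O)[O-])NCCCCOc1cccc(CN2CCCCC2)c1`, share a core and were both tested in a functional assay on cardiac atrium for antagonist activity at histamine H2 receptor (Cavia porcellus); a higher number here means a more potent compound, by a factor of ten per unit of this negative logarithm, a lower number a less potent compound. In this assay compound 1 gives 7.64, and compound 2 gives 7.85; the two values lie within the usual scatter of each other, so the numbers do not separate them. The untested compound 3, `N#CN/C(=N\CCNC(=O)c1ccncc1)NCCCOc1cccc(CN2CCCCC2)c1`, is built from compound 1 by one change: ((pyridin-4-yl)carbonyl)amino in place of benzoyloxy on a saturated chain carbon, two bonds along the chain from a double-bonded nitrogen. For the measured compounds named here, no measured pair here shows what such a swap does, so nothing in the data points to a step in either direction. The working expectation is therefore that the step from compound 1 to compound 3 is a number 0.06 log units higher from compound 1 to compound 3 (within the scatter), a change that stays within the scatter. On that basis compound 3 is expected to give 7.7 in this assay, in a range from 7 to 8.4.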

Compound 3, negative logarithm of the antagonist equilibrium constant: 6.89
Beside the measured number, compound 3's estimate is 0.81 log units above it, and the stated range ends above it.
By their numbers in this assay, from the lowest: compound 3; then compounds 1 and 2 (each within the scatter of the next).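

In this assay, this place on the chain proves to respond to what sits on it: ((pyridin-4-yl)carbonyl)amino in place of benzoyloxy gives a number 0.75 log units lower from compound 1 to compound 3 (beyond the scatter). The two groups both have 9 heavy atoms, one six-membered aromatic ring and one double bond outside aromatic rings, so the step appears even though these counts stay the same; what differs is the hetero atom in the ring, the nitrogen in the link and the hydrogen-bond donor that enters with it. No measurement at hand explains the step.

From the compounds shown here alone, the swap alters the link and the ring together, so it stays open which of the two goes with the step. Benzoylamino at this place, which keeps the carbon-only ring but has the amide link, would help to pull the two apart, as would ((pyridin-4-yl)carbonyl)oxy.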